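This account rests on a few compounds, and the source may have more. Where it says the series, first, only, none or still open, it means among the compounds named here.

Three compounds share one core and differ only in the group attached to a saturated chain carbon bound to a sulfur. Compound 1 `Cc1cc(S(=O)(=O)/N=C(\N)n2nccc2-c2ccccc2)c(SCc2cccc(Cl)c2)cc1Cl` carries a chlorophenyl group there, and in a functional assay on MCF7 cells (Homo sapiens) for cytotoxicity, read by MTT assay, with a stated time of 72 h (on this read-out higher numbers stand for weaker inhibition and lower numbers for stronger inhibition), compound 1 gives 88000 nM. Compound 2 `Cc1cc(S(=O)(=O)/N=C(\N)n2nccc2-c2ccccc2)c(SCc2cccc(C(F)(F)F)c2)cc1Cl` carries a trifluoromethyl-bearing phenyl instead, and in this assay compound 2 gives 17000 nM, a change of a 5.2-fold lower number from compound 1 to compound 2 (0.71 log units; beyond the scatter). Compound 3 `Cc1cc(S(=O)(=O)/N=C(\N)n2nccc2-c2ccccc2)c(SCc2ccccc2C(F)(F)F)cc1Cl` moves the trifluoromethyl to a different spot on that phenyl, and in this assay compound 3 gives 21000 nM. Compound 3 thus sits with compound 2 on the stronger side of the three, its step from compound 1 being a 4.2-fold lower number from compound 1 to compound 3 (0.62 log units; beyond the scatter), while the step of a 1.2-fold higher number from compound 2 to compound 3 (0.09 log units; within the scatter) shows the two trifluoromethyl compounds indistinguishable.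

Compound 4 `Cc1cc(S(=O)(=O)/N=C(\N)n2nccc2-c2ccccc2)c(SCc2ccc(Cl)cc2)cc1Cl` introduces (4-chlorophenyl in place of 2-(trifluoromethyl)phenyl on a saturated chain carbon bound to a sulfur). Going by the values given here, two measured steps bear on this: swapping trifluoromethyl for chloro gave a 5.2-fold lower number from compound 1 to compound 2 (0.71 log units; beyond the scatter) and a 4.2-fold lower number from compound 1 to compound 3 (0.62 log units; beyond the scatter) in the strengthening direction, whereas shifting a trifluoromethyl around the ring gave a 1.2-fold higher number from compound 2 to compound 3 (0.09 log units; within the scatter). Returning to a chloro-bearing phenyl is therefore expected to move the number back up toward compound 1, with the new position contributing little. The expected step is a 2.9-fold higher number from compound 3 to compound 4 (0.46 log units; beyond the scatter). Compound 4 is estimated at 60000 nM in this assay, within a range from 25000 nM to 150000 nM.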

Compound 4, half-maximal inhibitory concentration: 75000 nM
Beside the measured number, compound 4's estimate is 1.3-fold (0.10 log units) below it; measured number inside the range.
By their numbers in this assay, from the lowest: compounds 2 and 3 (each within the scatter of the next); then compounds 4 and 1 (each within the scatter of the next).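

In this assay, the two chlorophenyl compounds cannot be told apart, since 4-chlorophenyl in place of 3-chlorophenyl gives a 1.2-fold lower number from compound 1 to compound 4 (0.07 log units; within the scatter) and so stays within the usual scatter. The gaps to the trifluoromethyl compounds hold up with the new chloro compound, at a 3.6-fold higher number from compound 3 to compound 4 (0.55 log units; beyond the scatter) and a 4.4-fold higher number from compound 2 to compound 4 (0.64 log units; beyond the scatter) in this assay, so these four compounds fall into two pairs: in each pair the phenyl carries the same group, the location of that group on the ring does not separate the two members, and the choice of chloro or trifluoromethyl does separate the pairs. No measurement here accounts for this split between chloro and trifluoromethyl.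

The compounds shown leave open where an unsubstituted phenyl, a phenyl bearing a methoxy group or a phenyl bearing a carboxylic acid would fall, whether with one of the two pairs or apart from both. They also leave open whether a ring is needed at all on the saturated chain carbon bound to a sulfur, which a plain butyl chain in place of the phenyl would test.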